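Exchange on the amine nitrogen: from compound 2 to compound 3

The source may report more compounds than this note shows. Statements on the series, on what has been measured and on what is new or still open speak of the compounds shown alone.

Two members of this series have been measured in a functional assay (aorta) with Rattus norvegicus as the target; a lower number here means a stronger inhibitor, a higher number a weaker inhibitor. Compound 1 `CC1(C)Oc2ccc(C#N)cc2[C@@H](NC(=O)Nc2ccncc2)[C@@H]1O` gives 8500 nM. Compound 2 `CC1(C)Oc2ccc(C#N)cc2[C@@H](/N=C(\NC#N)Nc2ccc(C(F)(F)F)cc2)[C@@H]1O` gives 8100 nM. Compound 2 stands lowest of the two numbers, but its nearest neighbour, compound 1, lies within the scatter of it, so the two values show no difference that can be read as an order.

Compound 3 `CSc1cccc(N/C(=N/[C@@H]2c3cc(C#N)ccc3OC(C)(C)[C@H]2O)NC#N)c1` is the next compound to be measured in this assay. It differs from compound 2 in one place: 3-(methylsulfanyl)phenyl in place of 4-(trifluoromethyl)phenyl on an amine nitrogen. Within the data shown here, no step between measured compounds isolates this kind of exchange, so there is no measured precedent for it. The two measured compounds differ in more than one place and still give numbers within the scatter of each other, which gives no ground to expect a large move here. The expectation is a step of a 1.0-fold lower number from compound 2 to compound 3 (0.01 log units; within the scatter), that is, no change beyond the scatter. For compound 3 the estimate in this assay is 8000 nM, with a range from 3000 nM to 20000 nM.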

Compound 3, half-maximal inhibitory concentration: 1400 nM
Compound 3: the middle estimate sits 5.7-fold (0.76 log units) above what was measured, and the stated range ends above it.
By their numbers in this assay, from the lowest: compound 3; then compounds 2 and 1 (each within the scatter of the next).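

In this assay, among these compounds, the exchange of 4-(trifluoromethyl)phenyl for 3-(methylsulfanyl)phenyl on the amine nitrogen gives a 5.8-fold lower number from compound 2 to compound 3 (0.76 log units; beyond the scatter) and this is the first step that can be read across a single change. The aryl group on this nitrogen can therefore move the number while the rest of compound 2 stays the same, something the two earlier values, from compounds that differ in more than one place, could not show. The exchange replaces the group and alters where the substituent is named on the phenyl ring in one step, and nothing measured here accounts for the size of the move.

The compounds shown leave open whether the step follows the methylsulfanyl group itself or its place on the phenyl ring, a question that 4-(methylsulfanyl)phenyl and 3-(trifluoromethyl)phenyl on the same nitrogen would address. Also open is how far the sulfur matters, which 3-methoxyphenyl, 3-ethylphenyl or plain phenyl at this nitrogen would test in this assay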